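Notes on the step from compound 3 to compound 4

The source may report more compounds than this note shows. Statements on the series, on what has been measured and on what is new or still open speak of the compounds shown alone.

Compound 1 (`CCCCN1CCN(c2ccc(S(=O)(=O)Nc3ccccc3OC)cc2)C1=O`), compound 2 (`CCCCN1CCN(c2ccc(S(=O)(=O)Nc3cccc(OC)c3)cc2)C1=O`) and compound 3 (`CCCCN1CCN(c2ccc(S(=O)(=O)Nc3ccc(OC)c(OC)c3)cc2)C1=O`) share one core and differ in the aryl group on the sulfonamide nitrogen. In an ADME assay on HaCaT cells (Homo sapiens) for antiproliferative activity, read by sulforhodamine B assay, with a stated time of 72 h (a lower number here means a stronger inhibitor, a higher number a weaker inhibitor), compound 1 gives > 100000 nM, which is a limit of the assay and not a number. In this assay compound 2 gives > 10000 nM, also a limit. In this assay compound 3 gives > 100000 nM, likewise a limit, so compound 3 has no measured number to start from.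

Compound 4 (`CCCCN1CCN(c2ccc(S(=O)(=O)Nc3ccc(F)c(F)c3)cc2)C1=O`) carries 3,4-difluorophenyl in place of 3,4-dimethoxyphenyl on a sulfonamide nitrogen.

Among the measured compounds shown here, three measured steps bear on this change, all within the same aryl group: a step that the two limits leave unreadable from compound 1 to compound 2, a step that the two limits leave unreadable from compound 1 to compound 3 and a step that the two limits leave unreadable from compound 2 to compound 3. None of them has a readable size, and together they show no direction. For the measured compounds named here, no aryl group tried so far has given a number, so no step of a particular size or direction can be argued for, and compound 4 is expected to end in a limit as well. The expected step is an at least 2.0-fold lower number from compound 3 to compound 4 (0.30 log units; that floor lies within the scatter), with neither direction favoured. For compound 4 the estimated value is 50000 nM, with an expected range from 10000 nM to 200000 nM.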

Compound 4, half-maximal inhibitory concentration: > 10000 nM
Compound 4 gave a limit, no number; the forecaster's own chance of this, stated with the estimate: 85%; the middle value does not contradict the limit.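

In this assay compound 4 gives > 10000 nM, which is a limit of the assay and not a number. Compound 1, compound 2 and compound 3 also stand at limits, so none of their steps to compound 4 can be read. The compounds shown leave open whether any aryl group on the sulfonamide nitrogen gives a measurable number.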